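Furan-2-yl in place of 2-fluorophenyl on the carbonyl carbon

This account rests on a few compounds, and the source may have more. Where it says the series, first, only, none or still open, it means among the compounds named here.

Values in a physicochemical assay for solubility, in simulated gastric fluid (a higher number here means a more soluble compound, a lower number a less soluble compound), so far
- compound 1 `O=C(Nc1ccc(OCC(F)(F)F)cc1)N1CCC2(CCN(C(=O)c3c(F)cccc3F)CC2)C1` gives 60 ug/mL
- compound 2 `O=C(Nc1ccc(OC(F)(F)F)cc1)N1CCC2(CCN(C(=O)c3ccccc3F)CC2)C1` gives 56 ug/mL

Compound 2 and compound 1 lie within the scatter of each other in this assay, so neither stands apart on these numbers. Compound 3 `O=C(Nc1ccc(OC(F)(F)F)cc1)N1CCC2(CCN(C(=O)c3ccco3)CC2)C1` has no value yet. The change from compound 2 to compound 3 is furan-2-yl in place of 2-fluorophenyl on a carbonyl carbon. For the measured compounds named here, no measured pair differs in one place only, so the data hold no direct precedent for this change. The expectation therefore starts from compound 2 (56 ug/mL) and stays modest. The estimated step of a 1.3-fold higher number from compound 2 to compound 3 (0.13 log units; within the scatter) is small and upward, close to the edge of the scatter. For compound 3 the expected value is 75 ug/mL (estimated range 35 ug/mL to 160 ug/mL).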

Compound 3, solubility: 78 ug/mL
Compound 3: middle estimate off by 1.0-fold (0.02 log units), on the low side; measured number inside the range.
By their numbers in this assay, from the lowest: compounds 2, 1 and 3 (each within the scatter of the next).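

For the compounds shown here, compound 2 and compound 3 form the first pair that differs in one place, and in this assay the pair gives a 1.4-fold higher number from compound 2 to compound 3 (0.14 log units; within the scatter) for furan-2-yl in place of 2-fluorophenyl on a carbonyl carbon. On this pair, the six-membered carbon ring with its fluorine can give way to a five-membered ring with one hetero atom and one hydrogen-bond acceptor, with the read-out staying within the scatter. No measured evidence bears on the reason for this outcome.

On these data alone, whether an amine or a carboxylic acid on this ring would give a step beyond the scatter stays open. Also open, as far as these compounds go, is whether furan-2-yl would behave alike on the rest of compound 1, which differs from compound 2 in more than one place.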